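Compound 3 to compound 4: one added methyl

The source may report more compounds than this note shows. Statements on the series, on what has been measured and on what is new or still open speak of the compounds shown alone.

compound 1 `CC(=O)c1s/c(=N\NC(=O)COc2ccc3c(-c4ccccc4)cc(=O)oc3c2)n(C)c1C` gives 42 ug/mL
compound 2 `CCn1c(C)c(C(C)=O)s/c1=N\NC(=O)COc1ccc2c(-c3ccccc3)cc(=O)oc2c1` gives 28 ug/mL
compound 3 `CCOC(=O)C(S/C(=N/NC(=O)COc1ccc2c(-c3ccccc3)cc(=O)oc2c1)NC)C(C)=O` gives 30.6 ug/mL

These values come from a functional assay on MCF7 cells (Homo sapiens) for inhibition, read by MTT assay, with a stated time of 48 h (on this read-out lower numbers stand for stronger inhibition and higher numbers for weaker inhibition), and all lie within the scatter of one another. Compound 3 lies nearest to compound 2 and furthest from compound 1 in number, with both gaps inside the scatter. Compound 4 `CCN/C(=N\NC(=O)COc1ccc2c(-c3ccccc3)cc(=O)oc2c1)SC(C(C)=O)C(=O)OCC` differs from compound 3 by methyl in place of hydrogen on a saturated chain carbon bound to an amine nitrogen and so reads methylamino to ethylamino. Among the measured compounds shown here, the one measured step that bears on this is methyl in place of hydrogen on a saturated chain carbon bound to an aromatic nitrogen, which gave a 1.5-fold lower number from compound 1 to compound 2 (0.18 log units; within the scatter) and no more. In this assay the expected step is a 1.2-fold lower number from compound 3 to compound 4 (0.07 log units; within the scatter) and nothing beyond the scatter is expected. For compound 4 the estimated value is 26 ug/mL with an expected range of 14 ug/mL to 46 ug/mL in this series.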

Compound 4, half-maximal inhibitory concentration: 41.9 ug/mL
Beside the measured number, compound 4's estimate is 1.6-fold (0.21 log units) below it; the measured number falls inside the stated range.
By their numbers in this assay, from the lowest: compounds 2, 3, 4 and 1 (each within the scatter of the next).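

In this assay, methylamino to ethylamino gives a 1.4-fold higher number from compound 3 to compound 4 (0.14 log units; within the scatter), so this amine position accepts the added methyl with no step beyond the scatter. The same change can now be read on two cores, and the two steps cannot be told apart: the same change on two cores in this assay, a 1.5-fold lower number (0.18 log units; within the scatter) from compound 1 to compound 2 and a 1.4-fold higher number (0.14 log units; within the scatter) from compound 3 to compound 4, 2.1-fold (0.31 log units) apart, within the scatter of two such steps

The compounds shown leave open whether a longer chain such as propyl or butyl on this amine nitrogen would move the number beyond the scatter. A carboxylic acid or a terminal amine on that chain also remains an open question.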